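A few compounds are considered here, and "the series" means these few. Any claim that something is new, unique, unknown or untested is made for them only; others in the source may bear on it.

Working notes on the series. In a functional assay on HT-29 cells (Homo sapiens) for cytotoxicity, read by sulforhodamine B assay, with a stated time of 2 days, tested at 100 uM (on this read-out lower numbers stand for less inhibition and higher numbers for more inhibition at the one concentration tested (going by the name of the read-out)), compound 1 `O=C(Nn1c(-c2cccc([N+](=O)[O-])c2)nc2c(-c3ccco3)n[nH]c2c1=O)c1cccnc1` gives 11.7%. In this assay compound 2 `CCCc1n[nH]c2c(=O)n(NC(=O)c3ccccc3)c(-c3cccc([N+](=O)[O-])c3)nc12` gives 18.7%. In this assay compound 3 `O=C(Nn1c(CCc2ccccc2)nc2c(-c3ccc(Cl)cc3)n[nH]c2c1=O)c1ccccc1` gives 86.5%, the highest of the three numbers; the nearest, compound 2, lies beyond the scatter below it, and compound 1 lies further below still. Among the compounds with values here, compound 1 and compound 2 each differ from compound 3 in more than one place, so the three measured numbers give no step that isolates a single change.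

Compound 4 `CCCCCc1nc2c(-c3ccc(Cl)cc3)n[nH]c2c(=O)n1NC(=O)c1ccccc1` has not yet been measured in this assay. It differs from compound 3 in one place: propyl in place of phenyl on a saturated chain carbon, two bonds along the chain from an aromatic carbon. Cut one bond further out, phenethyl becomes pentyl. Within the data shown here, no measured pair in the set covers this change, so the size of the step rests on judgement alone. In this assay the expected step is a number 21.5 percentage points lower from compound 3 to compound 4 (beyond the scatter), a downward move of moderate size, though a step within the scatter cannot be excluded. Compound 4 is expected to give 65% in this assay, with a range from 30% to 90%.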

Compound 4, a percentage reported as inhibition, at one concentration (the size of the read-out at that concentration, not a potency): 90.1%
The estimate for compound 4 lay 25.1 percentage points below the measured number; the whole stated range lies below it.
By their numbers in this assay, from the lowest: compounds 1 and 2 (each within the scatter of the next); then compounds 3 and 4 (each within the scatter of the next).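

In this assay the step at this position reads a number 3.6 percentage points higher from compound 3 to compound 4 (within the scatter), so propyl in place of phenyl on a saturated chain carbon, two bonds along the chain from an aromatic carbon, gives no difference beyond the scatter. For this one pair, the terminal phenyl of the phenethyl group is therefore not needed to hold a number of this size; pentyl serves equally well with the rest of compound 3 unchanged. Nothing on hand bears on why the two compounds read alike.

From the compounds shown here alone, whether an amine or a carboxylic acid at the end of the chain, or a much shorter chain such as ethyl, would keep the number in this range remains open. Compound 1 and compound 2 differ from compound 4 in more than one place, so the change that separates them from it cannot be isolated.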